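The compounds below may be only part of what the source reports. "The series", "measured", "known", "first", "only" and "open" are said of these compounds alone.

Compound 1 `FC(F)(F)c1ccccc1-c1ccc2[nH]c(C3=NOC4(CCCCC4)C3)nc2c1` is the reference point of this pair. In an ADME assay on microsomes from liver (Rattus norvegicus) for metabolic stability, with a stated time of 10 min (on this read-out higher numbers stand for a more stable compound and lower numbers for a less stable compound), compound 1 gives 75%. For the measured compounds named here, compound 2 `FC(F)Oc1ccccc1-c1ccc2[nH]c(C3=NOC4(CCCCC4)C3)nc2c1` is the only other measured member; in this assay compound 2 gives 59%. Going by the values given here, the one measured step is a number 16 percentage points lower from compound 1 to compound 2 (beyond the scatter), so compound 1 stands highest of the two numbers, and its nearest neighbour is compound 2.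

Compound 3 `Fc1cccc(C(F)(F)F)c1-c1ccc2[nH]c(C3=NOC4(CCCCC4)C3)nc2c1` is not yet measured. Relative to compound 1 it carries fluoro in place of hydrogen on an aromatic carbon, while the trifluoromethyl group of compound 1 is kept. Among the compounds with values here, the step from compound 1 to compound 2 is the only measured step and concerns a different change, the exchange of the trifluoromethyl group itself; it shows that a change at this part of the molecule can move this assay by a modest amount, but no measured step covers the addition of a fluoro group. Within the data shown here, with no direct precedent, the expectation for compound 3 is a step of a number 2 percentage points higher from compound 1 to compound 3 (within the scatter), that is, within the scatter. For compound 3 the estimated value in this assay is therefore 77%, with a range from 62% to 90%.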

Compound 3, percent of the compound remaining: 37%
Compound 3: middle estimate off by 40 percentage points, on the high side; the whole stated range lies above it.
By their numbers in this assay, from the lowest: compound 3; then compound 2; then compound 1.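

In this assay the addition reads as a number 38 percentage points lower from compound 1 to compound 3 (beyond the scatter) for a fluoro group in place of hydrogen, on an aromatic carbon ortho to a large group and meta to a trifluoromethyl group. One added fluorine atom at this place therefore moves the read-out further than the exchange of the trifluoromethyl group itself, which is a number 16 percentage points lower from compound 1 to compound 2 (beyond the scatter) and which left this carbon unchanged, so this carbon is now a site of large change in the series, even with the trifluoromethyl group kept. Nothing at hand bears on what lies behind this step, and it stands as an observation only.

The compounds shown leave open whether the step belongs to fluoro in particular or would follow any substituent on this carbon, a question that a chlorine atom, a methyl group or a methoxy group at the same place would help to settle. They also leave open whether the same fluoro group would have a step of similar size with difluoromethoxy in place of trifluoromethyl, or on another carbon of the same ring.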